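Dimethoxyphenyl Replaces Methylphenyl on the Triazole Nitrogen

This account rests on a few compounds, and the source may have more. Where it says the series, first, only, none or still open, it means among the compounds named here.

Compound 1, `Cc1ccc(-n2nncc2CN2C(=O)C3(C(C#N)=C(N)Oc4c3c3nc5ccccc5nc3c3ccccc43)c3ccccc32)cc1Cl`: in a functional assay on HCT-116 cells (Homo sapiens) for antiproliferative activity, read by MTT assay, with a stated time of 48 h (a lower number here means a stronger inhibitor, a higher number a weaker inhibitor), compound 1 reaches only the assay limit, > 50000 nM.
Compound 2, `N#CC1=C(N)Oc2c(c3nc4ccccc4nc3c3ccccc23)C12C(=O)N(Cc1cnnn1-c1ccc(Cl)c(Cl)c1)c1ccccc12`: in this assay compound 2 likewise shows only the limit, > 50000 nM.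
Compound 3, `Cc1ccccc1-n1nncc1CN1C(=O)C2(C(C#N)=C(N)Oc3c(N)cc4nc5ccccc5nc4c32)c2ccccc21`: in this assay compound 3 also gives only the limit, > 50000 nM.

Compound 3 therefore stands at the limit, as do the other two measured compounds (the limit of > 50000 nM in this assay, at which 3 of the 3 values shown sit). Among the measured compounds shown here, the one measured step, the one from compound 1 to compound 2 with chloro in place of methyl on an aromatic carbon, is a step that the two limits leave unreadable from compound 1 to compound 2, so it tells nothing about size or direction.

Compound 4, `COc1ccc(OC)c(-n2nncc2CN2C(=O)C3(C(C#N)=C(N)Oc4c(N)cc5nc6ccccc6nc5c43)c3ccccc32)c1`, differs from compound 3 by 2,5-dimethoxyphenyl in place of 2-methylphenyl on an aromatic nitrogen. For the measured compounds named here, no measured step touches a change of this kind, and the only step available is unreadable, so nothing argues for a move off the limit. The estimated step from compound 3 to compound 4 is a number no higher from compound 3 to compound 4 (the limit leaves the size open). Compound 4 is thus expected to give about 50000 nM, within 15000 nM to 150000 nM, most likely again reported only as a limit.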

Compound 4, half-maximal inhibitory concentration: > 50000 nM
Compound 4 ended at the assay's limit (the forecaster's own chance of this, stated with the estimate: 80%); the middle value sits exactly at the limit.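

Compound 3 and compound 4 both stand at the assay limit, so the step between them cannot be read, in size or in direction: the limit of > 50000 nM in this assay, at which 4 of the 4 values shown sit.

The compounds shown leave open whether any change to the shared core would give a measurable value in this assay.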